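Testing a Cyclopropyl Group in Deacetylase Inhibition Assays

The source may report more compounds than this note shows. Statements on the series, on what has been measured and on what is new or still open speak of the compounds shown alone.

Measured compounds:
compound 1, `CC(C)(C(=O)Nc1ccc(C(=O)Nc2ccc(F)cc2N)cc1)c1ccccc1`: 4%
compound 2, `CC(C)[C@@H](C(=O)Nc1ccc(C(=O)Nc2ccc(C(F)(F)F)cc2N)cc1)c1ccccc1`: 0%
compound 3, `CC(C)[C@@H](C(=O)Nc1ccc(C(=O)Nc2ccc(F)cc2N)cc1)c1ccccc1`: 0%

Three compounds sharing one core were tested in an assay on isolated protein for inhibition of protein deacetylase HDAC6 (Homo sapiens), read by fluorescence, tested at 1 uM; a higher number here means more inhibition at the concentration tested (going by the name of the read-out), a lower number less inhibition. Compound 3 stands level with compound 2 at the digits shown, and these two are together the lowest of the three numbers; compound 1 sits furthest away, yet the step of a number 4 percentage points lower from compound 1 to compound 3 (within the scatter) lies within the usual scatter, as does no change at the digits printed from compound 2 to compound 3 (within the scatter). In short, none of the three shows inhibition worth the name at the tested concentration.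

Compound 4, `Nc1cc(F)ccc1NC(=O)c1ccc(NC(=O)C2CC2c2ccccc2)cc1`, is not yet measured. It differs from compound 3 in one place: 2-phenylcyclopropyl in place of 2-methyl-1-phenylpropyl on a carbonyl carbon. Among the compounds with values here, the one earlier step that touches the same carbonyl carbon, a number 4 percentage points lower from compound 1 to compound 3 (within the scatter), changed nothing beyond the scatter, and the group entering is of similar size to the group leaving. The expected step of a number 3 percentage points higher from compound 3 to compound 4 (within the scatter) is therefore none beyond the scatter. Compound 4 is estimated to give 3% in this assay, within a range of -6% to 15%.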

Compound 4, a percentage reported as inhibition, at one concentration (the size of the read-out at that concentration, not a potency): 0%
Estimate against measurement, compound 4: 3 percentage points above, and the stated range covers the measured number.
By their numbers in this assay, from the lowest: compounds 2, 3, 4 and 1 (each within the scatter of the next).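

In this assay the 2-phenylcyclopropyl group on the carbonyl carbon brings no change at the digits printed from compound 3 to compound 4 (within the scatter) and, set against the 1-methyl-1-phenylethyl group, a number 4 percentage points lower from compound 1 to compound 4 (within the scatter) (both steps are the whole effect of this change). A three-membered ring in this group therefore adds a new kind of group at this position, yet the numbers for all three groups tried there, on the same fluoro-bearing core, stay within the scatter of one another and show no real inhibition at the tested concentration. Nothing measured here gives a reason for this flat picture.

Going by these compounds, it remains open whether any group at this carbonyl carbon can lift the number at all, for example one carrying an amine or a carboxylic acid. A reading at a single concentration also leaves open whether these compounds would show inhibition at higher concentrations.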